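The source may report more compounds than this note shows. Statements on the series, on what has been measured and on what is new or still open speak of the compounds shown alone.

Compound 1 `C=C[C@@](C)(/C=C/c1ccc(OCc2ccccc2)cc1)CCC=C(C)C` was tested in an ADME assay on BJ cells (Homo sapiens) for cytotoxicity, with a stated time of 72 h; a higher number here means that more compound is needed for the effect, a lower number that less compound is needed. In this assay compound 1 reaches only a limit of the assay at > 36600 nM and gives no number. Compound 2 `C=C[C@@](C)(/C=C/c1ccc(O)cc1)CCC=O` likewise gives only a limit in this assay at > 36600 nM. Compound 3 `C=C[C@@](C)(/C=C/c1ccc(O)cc1)CCCO` also gives only a limit in this assay at > 36600 nM. Among the compounds with values here, the single step between measured compounds that differ in one place, a step that the two limits leave unreadable from compound 2 to compound 3, is accordingly unreadable, since every measured value sits at the limit of > 36600 nM in this assay, at which 3 of the 3 values shown sit. The unmeasured compound 4 `C=C[C@@](C)(/C=C/c1ccc(-c2ccc(Cl)c(Cl)c2)cc1)CCC=C(C)C` differs from compound 1 by 3,4-dichlorophenyl in place of benzyloxy on an aromatic carbon. Within the data shown here, no measured step covers an exchange of this kind, so the measured compounds offer no direction for this assay; the only guide is that compound 1 itself returns no number. The step expected here, an at least 1.2-fold lower number from compound 1 to compound 4 (0.08 log units; that floor lies within the scatter), is one that stays within the scatter, with another limit the most probable outcome. The estimate for compound 4 in this assay is 30000 nM, with a range from 7000 nM to 90000 nM.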

Compound 4, half-maximal effective concentration: > 36600 nM
Compound 4 ended at the assay's limit; the forecaster's own chance of this, stated with the estimate: 65%; middle value at least 1.2-fold (0.08 log units) from the limit.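

Compound 1 and compound 4 both end at a limit in this assay, so no step can be read between them: the limit of > 36600 nM in this assay, at which 4 of the 4 values shown sit.

The compounds shown leave open whether any change to the shared core would yield an actual number in this assay.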